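Swapping an Ester for a Methyl Under a Cytotoxicity Ceiling

This account rests on a few compounds, and the source may have more. Where it says the series, first, only, none or still open, it means among the compounds named here.

Compound 1, `O=C(CSc1snnc1-c1ccccc1)Nc1ccccc1F`: in an ADME assay on MT4 cells (Homo sapiens) for cytotoxicity (on this read-out lower numbers stand for higher toxicity in this test and higher numbers for lower toxicity in this test), compound 1 gives > 361000 nM, which is a limit of the assay.
Compound 2, `CCOC(=O)c1ccc(NC(=O)CSc2snnc2-c2ccccc2)c(Br)c1`: in this assay compound 2 gives >= 232000 nM, again a limit of the assay.
Compound 3, `CCOC(=O)c1ccc(NC(=O)CSc2snnc2-c2ccc(Cl)cc2Cl)c(Br)c1`: in this assay compound 3 gives > 228000 nM, also a limit of the assay.

Among the compounds with values here, compound 2 therefore stands only at a limit, and the two other values shown are limits as well, so no compound here can be ranked against another. Within the data shown here, the single change that has been measured, a step that the two limits leave unreadable from compound 2 to compound 3, cannot be read at all, since both ends sit at limits (the limit of >= 232000 nM in this assay, at which 1 of the 3 values shown sits, and (the limit of > 228000 nM in this assay, at which 1 of the 3 values shown sits)). The unmeasured compound 4, `Cc1ccc(NC(=O)CSc2snnc2-c2ccccc2)c(Br)c1`, differs from compound 2 by methyl in place of ethoxycarbonyl on an aromatic carbon. Among the measured compounds shown here, no measured step speaks to this exchange, and nothing among the three values, all of them limits (the limit of > 361000 nM in this assay, at which 1 of the 3 values shown sits, included), suggests that any member of this series reaches a measurable toxicity. The expectation for compound 4 is accordingly that it too stays at the limit, with an estimated step that the limit leaves unreadable from compound 2 to compound 4 in this assay, meaning no change beyond the scatter. Compound 4 is expected to give about 250000 nM, within a range from 100000 nM to 400000 nM.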

Compound 4, half-maximal cytotoxic concentration: > 297000 nM
Compound 4: no number, only a limit; the forecaster's own chance of this, stated with the estimate: 85%; middle value at least 1.1-fold (0.07 log units) from the limit.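

In this assay compound 4 gives > 297000 nM, which is a limit of the assay and not a number. Its steps from compound 2 and from compound 1 join limits at both ends and cannot be read. The compounds shown leave open at what concentration any of them becomes toxic to these cells, and whether methyl and ethoxycarbonyl differ there.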